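The source may report more compounds than this note shows. Statements on the series, on what has been measured and on what is new or still open speak of the compounds shown alone.

Measured so far:
compound 1 `Cc1ccnc(/C(N)=N/NC(=S)N2CCOCC2)c1`: 87.4%
compound 2 `Cc1cccc(/C(N)=N/NC(=S)N2CCSCC2)n1`: 73.1%
compound 3 `Cc1ccnc(/C(N)=N/NC(=S)N2CCSCC2)c1`: 84.9%

In a functional assay on A-375 cells (Homo sapiens) for cytotoxicity, read by MTT assay, with a stated time of 72 h, tested at 30 uM (a higher number here means more inhibition of growth at the concentration tested, a lower number less inhibition of growth), compound 1 gives 87.4%, compound 3 gives 84.9% and compound 2 gives 73.1%, the lowest of the three. Compound 2 and compound 3 are built from the same atoms joined differently; the difference between their two cores is not broken down here. From compound 3 to compound 1 the change is morpholin-4-yl in place of thiomorpholin-4-yl on a thiocarbonyl carbon, and the step was a number 2.5 percentage points higher from compound 3 to compound 1 (within the scatter). Compound 4 `Cc1cccc(/C(N)=N/NC(=S)N2CCOCC2)n1` is not yet measured; it differs from compound 2 by morpholin-4-yl in place of thiomorpholin-4-yl on a thiocarbonyl carbon, the same change at the same place. The step from compound 2 to compound 4 is therefore expected to be about a number 2.4 percentage points higher from compound 2 to compound 4 (within the scatter), resting on the small step seen from compound 3 to compound 1 a number 2.5 percentage points higher from compound 3 to compound 1 (within the scatter). In this assay compound 4 is thus estimated at 75.5%, likely between 63% and 86%.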

Compound 4, percent growth inhibition at one concentration: 74.3%
Compound 4: middle estimate off by 1.2 percentage points, on the high side, within the range that was stated.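

In this assay, putting morpholin-4-yl in place of thiomorpholin-4-yl on the thiocarbonyl carbon gives a number 1.2 percentage points higher from compound 2 to compound 4 (within the scatter). Set beside the same change on the other core, the result agrees: the same change on two cores in this assay, a number 2.5 percentage points higher (within the scatter) from compound 3 to compound 1 and a number 1.2 percentage points higher (within the scatter) from compound 2 to compound 4, 1.3 percentage points apart, within the scatter of two such steps. So on these two cores the swap carries over as a change too small to tell from scatter, but two cores cannot show that it would stay this small on a third, and this single test concentration cannot show a difference between the two rings.

The compounds shown leave open what other groups would do on the thiocarbonyl carbon, such as a piperidin-1-yl ring or an open-chain diethylamino group. Only these two rings can be compared there.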